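Three Thiadiazole Amides at the Cytotoxicity Limit, a Fourth Awaited

This account rests on a few compounds, and the source may have more. Where it says the series, first, only, none or still open, it means among the compounds named here.

Measured compounds:
compound 1, `CC(Sc1nnc(-c2ccncc2)s1)C(=O)NCc1ccccc1Cl`, > 50000 nM
compound 2, `CC(Sc1nnc(-c2ccncc2)s1)C(=O)Nc1ccc(Cl)cc1`, > 50000 nM
compound 3, `CC(CSc1nnc(-c2ccncc2)s1)C(=O)NCc1ccccc1Cl`, > 50000 nM

Three amides built on a shared thiadiazole-pyridine core were tested in an ADME assay on BHK-21 cells (Mesocricetus auratus) for cytotoxicity, with a stated time of 3 days; on this read-out higher numbers stand for lower toxicity in this test and lower numbers for higher toxicity in this test. Compound 1 `CC(Sc1nnc(-c2ccncc2)s1)C(=O)NCc1ccccc1Cl` reaches only the limit of the test, > 50000 nM, and no number is reported for it. Compound 2 `CC(Sc1nnc(-c2ccncc2)s1)C(=O)Nc1ccc(Cl)cc1` likewise sits at a limit in this assay, > 50000 nM. Compound 3 `CC(CSc1nnc(-c2ccncc2)s1)C(=O)NCc1ccccc1Cl` also returns a limit in this assay, > 50000 nM.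

Compound 2 differs from compound 1 by one change, (4-chlorophenyl in place of 2-chlorobenzyl on an amide-type nitrogen). The resulting step in this assay is a step that the two limits leave unreadable from compound 1 to compound 2, since both ends are limits. The difference between the core of compound 1 and the core of compound 3 is not broken down here.

Compound 4 `CC(CSc1nnc(-c2ccncc2)s1)C(=O)Nc1ccc(Cl)cc1` has not yet been measured in this assay. It differs from compound 3 by the same change, (4-chlorophenyl in place of 2-chlorobenzyl on an amide-type nitrogen). Among the compounds with values here, the three measured compounds all sit at the limit of > 50000 nM in this assay, at which 3 of the 3 values shown sit, which gives the only guide to what compound 4 may show. The step from compound 3 to compound 4 is expected to be a step that the limit leaves unreadable from compound 3 to compound 4, because compound 1 and compound 2 gave a step that the two limits leave unreadable from compound 1 to compound 2 that the limits left unreadable. Compound 4 is expected to show about 80000 nM in this assay, most likely again reported only as a limit, within a range from 30000 nM to 300000 nM.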

Compound 4, half-maximal cytotoxic concentration: > 50000 nM
Compound 4: only a limit was reported; the forecaster's own chance of this, stated with the estimate: 85%; the middle value is on the limit's open side.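

In this assay compound 4 gives > 50000 nM as a limit, not a number. Compound 3 also stands at a limit, and no new step can be read from compound 3 to compound 4 for 4-chlorophenyl in place of 2-chlorobenzyl on the amide-type nitrogen. The compounds shown leave open how far each of the four lies past the limit, and whether either change alters the read-out at all.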